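This account rests on a few compounds, and the source may have more. Where it says the series, first, only, none or still open, it means among the compounds named here.

Compound 1 `COc1ccc(Nc2nc3ccccc3nc2S(=O)(=O)c2ccc(OC)cc2)cc1` gives 1190 nM in a functional assay on HL-60 cells (Homo sapiens) for cytotoxicity, read by MTT assay, with a stated time of 72 h; a lower number here means a stronger inhibitor, a higher number a weaker inhibitor. Compound 2 `COc1ccc(S(=O)(=O)c2nc3ccccc3nc2Nc2cc(OC)cc(OC)c2)cc1` carries 3,5-dimethoxyphenyl in place of 4-methoxyphenyl on a nitrogen on an aromatic ring and gives 1710 nM, so the step of a 1.4-fold higher number from compound 1 to compound 2 (0.16 log units; within the scatter) is small. Compound 3 `COc1ccc(Nc2nc3ccccc3nc2S(=O)(=O)c2ccc(F)cc2)cc1` differs from compound 1 by fluoro in place of methoxy on an aromatic carbon; compound 3 gives 1200 nM, and the step of a 1.0-fold higher number from compound 1 to compound 3 (0.00 log units; within the scatter) shows no movement. Compound 4 `COc1cc(Nc2nc3ccccc3nc2S(=O)(=O)c2ccc(F)cc2)cc(OC)c1` has not yet been measured; it differs from compound 3 by 3,5-dimethoxyphenyl in place of 4-methoxyphenyl on a nitrogen on an aromatic ring, the same change that turned compound 1 into compound 2, and the cores of compound 3 and compound 4 differ from those of compound 1 and compound 2 by fluoro in place of methoxy on an aromatic carbon. Because the earlier step of a 1.4-fold higher number from compound 1 to compound 2 (0.16 log units; within the scatter) stayed within the scatter, the step from compound 3 to compound 4 is expected to be similar, a 1.4-fold higher number from compound 3 to compound 4 (0.15 log units; within the scatter). Compound 4 is therefore expected to give 1700 nM in this assay, estimated between 900 nM and 3400 nM.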

Compound 4, half-maximal inhibitory concentration: 2360 nM
Estimate against measurement, compound 4: 1.4-fold (0.14 log units) below; measured number inside the range.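

In this assay the change to 3,5-dimethoxyphenyl on the core of compound 3 reads as a 2.0-fold higher number from compound 3 to compound 4 (0.29 log units; within the scatter), and it carries over between the two cores: the same change on two cores in this assay, a 1.4-fold higher number (0.16 log units; within the scatter) from compound 1 to compound 2 and a 2.0-fold higher number (0.29 log units; within the scatter) from compound 3 to compound 4, 1.4-fold (0.14 log units) apart, within the scatter of two such steps. The change to fluoro, read here as a 1.4-fold higher number from compound 2 to compound 4 (0.14 log units; within the scatter), carries over in the same way: the same change on two cores in this assay, a 1.0-fold higher number (0.00 log units; within the scatter) from compound 1 to compound 3 and a 1.4-fold higher number (0.14 log units; within the scatter) from compound 2 to compound 4, 1.4-fold (0.14 log units) apart, within the scatter of two such steps. This shows that neither change moved the number beyond the scatter on these cores, but with steps this small it does not show that either change has a real effect, or that the agreement would hold on any other core.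

The compounds shown leave open what an amine, a carboxylic acid or a longer chain would do in place of the methoxy or fluoro groups. They also leave open whether a change to the shared core itself would give a larger step.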